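The compounds below may be only part of what the source reports. "The series", "measured", "known", "first", "only" and "open" are said of these compounds alone.

Compound 1, `O=C1O[C@H]([C@@H](O)Cn2cc(CNS(=O)(=O)c3ccc(F)cc3)nn2)C(OCc2ccccc2)=C1OCc1ccccc1`: 18300 nM.
Compound 2, `O=C1O/C(=C\Cn2cc(-c3cccc(O)c3)nn2)C(OCc2ccccc2)=C1OCc1ccccc1`: 61700 nM.
Compound 3, `COc1ccccc1-c1cn(C/C=C2\OC(=O)C(OCc3ccccc3)=C2OCc2ccccc2)nn1`: in this assay compound 3 reaches only a limit, > 100000 nM.

In a functional assay on HepG2 cells (Homo sapiens) for antiproliferative activity, read by MTT assay, with a stated time of 72 h (on this read-out lower numbers stand for stronger inhibition and higher numbers for weaker inhibition), compound 1 holds the lowest of the two numbers; compound 2 sits higher by a margin beyond the scatter. Among the measured compounds shown here, the only measured step, an at least 1.6-fold higher number from compound 2 to compound 3 (0.20 log units; that floor lies within the scatter), concerns a different change at a different place and rests on a limit, (the limit of > 100000 nM in this assay, at which 1 of the 3 values shown sits), so it does not bear on the change at hand. Compound 4, `O=C1O[C@H]([C@@H](O)Cn2cc(CNS(=O)(=O)c3ccc(Cl)cc3)nn2)C(OCc2ccccc2)=C1OCc1ccccc1`, differs from compound 1 by chloro in place of fluoro on an aromatic carbon. For the measured compounds named here, with no comparable step among the measured compounds, no shift beyond the scatter is expected, and compound 4 is estimated at 16000 nM, between 7000 nM and 36000 nM, meaning an expected step of a 1.1-fold lower number from compound 1 to compound 4 (0.06 log units; within the scatter).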

Compound 4, half-maximal inhibitory concentration: 7510 nM
Beside the measured number, compound 4's estimate is 2.1-fold (0.33 log units) above it, and the stated range covers the measured number.
By their numbers in this assay, from the lowest: compound 4; then compound 1; then compound 2. At a limit, above all of these: compound 3.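

In this assay, the step of a 2.4-fold lower number from compound 1 to compound 4 (0.39 log units; beyond the scatter) shows that this place, on an aromatic carbon para to a large group, responds to a change of one halogen, with chloro giving the lower number and so the stronger inhibition. The earlier compounds shown here held no change at this place. Nothing measured here accounts for the size of this step. From the compounds shown here alone, whether bromo, methyl, methoxy or an amine at this place would lower the number further stays open, as does whether the same exchange would give a similar step on another side chain.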